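Replacing One Group on an Amide-Type Nitrogen

The source may report more compounds than this note shows. Statements on the series, on what has been measured and on what is new or still open speak of the compounds shown alone.

In a functional assay on MCF7 cells (Homo sapiens) for antiproliferative activity, with a stated time of 72 h (a lower number here means that less compound is needed, a higher number that more compound is needed for the effect), compound 1 `CNC(=O)c1ccc(N(Cc2ccc(C3CCCCC3)cn2)C(=O)[C@H]2CCN2S(=O)(=O)c2c(F)c(F)c(F)c(F)c2F)c(F)c1` is recorded as "not determined" (no result reported). Going by the values given here, compound 2 `O=C([C@H]1CCN1S(=O)(=O)c1c(F)c(F)c(F)c(F)c1F)N(Cc1ccc(C2CCCCC2)cn1)c1ccc2c(=O)[nH]cnc2c1` gives 3600 nM, the only number available, so it can be ranked against no other compound. Compound 3 `O=C1NC(=O)c2cc(N(Cc3ccc(C4CCCCC4)cn3)C(=O)[C@H]3CCN3S(=O)(=O)c3c(F)c(F)c(F)c(F)c3F)ccc21` differs from it on an amide-type nitrogen: a group of 11 heavy atoms (8 carbon, 1 nitrogen, 2 oxygen; one five-membered non-aromatic ring with 1 hetero atom, one six-membered aromatic ring of carbon only) in place of a group of 11 heavy atoms (8 carbon, 2 nitrogen, 1 oxygen; one six-membered aromatic ring of carbon only, one six-membered aromatic ring with 2 hetero atoms), on an amide-type nitrogen. Among the compounds with values here, no measured step is available to guide a comparison. The step expected in this assay is a 1.1-fold higher number from compound 2 to compound 3 (0.05 log units; within the scatter), which means none beyond the usual scatter and no clear direction. Compound 3 is estimated at 4000 nM, with an expected range from 1500 nM to 12000 nM.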

Compound 3, half-maximal effective concentration: 7000 nM
The estimate for compound 3 lay 1.8-fold (0.24 log units) below the measured number; measured number inside the range.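

In this assay, going by these compounds alone, the exchange on the amide-type nitrogen, a five-membered non-aromatic ring with 1 hetero atom entering where a six-membered aromatic ring with 2 hetero atoms stood, gives a 1.9-fold higher number from compound 2 to compound 3 (0.29 log units; within the scatter) and so the first readable comparison at this position does not separate the two groups of 11 heavy atoms. Nothing measured here bears on this result. The compounds shown leave open whether a different group on this nitrogen, such as a plain phenyl ring or a carboxylic acid, would move the number beyond the scatter. Compound 1 has no reported result, so its group cannot be compared.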